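Nitro to pentyl on the phenoxy ring

The compounds below may be only part of what the source reports. "The series", "measured", "known", "first", "only" and "open" are said of these compounds alone.

Compound 1 `COC(=O)c1cccc(NC(=O)COc2ccc(C(C)(C)CC(C)(C)C)cc2)c1` gives 6650 nM in an assay for inhibition of malate dehydrogenase, cytoplasmic (Homo sapiens), with a stated time of 30 min; on this read-out lower numbers stand for stronger inhibition and higher numbers for weaker inhibition.
Compound 2 `COC(=O)c1cccc(NC(=O)COc2ccc([N+](=O)[O-])cc2)c1` gives > 40000 nM in this assay.

Compound 2 sits at a limit of the assay and not at a number: the limit of > 40000 nM in this assay, at which 1 of the 2 values shown sits. Going by the values given here, the one measured step, an at least 6.0-fold higher number from compound 1 to compound 2 (0.77 log units; beyond the scatter), shows that exchanging the branched alkyl group for nitro weakens inhibition at least modestly.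

Compound 3 `CCCCCc1ccc(OCC(=O)Nc2cccc(C(=O)OC)c2)cc1` carries a straight alkyl chain in the same position: pentyl in place of nitro on an aromatic carbon. This reverses the direction of the measured step, since pentyl and 1,1,3,3-tetramethylbutyl are both alkyl groups, whereas nitro is not; the step is therefore expected to run toward stronger inhibition, though pentyl is the shorter chain and compound 1 gives the reference of 6650 nM.

Compound 3 is estimated at 12000 nM in this assay, within 4000 nM to 40000 nM. The expected step is an at least 3.3-fold lower number from compound 2 to compound 3 (0.52 log units; beyond the scatter).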

Compound 3, half-maximal inhibitory concentration: 6790 nM
Estimate against measurement, compound 3: 1.8-fold (0.25 log units) above; low and high end bracket the measured number.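

In this assay, pentyl in place of 1,1,3,3-tetramethylbutyl gives a 1.0-fold higher number from compound 1 to compound 3 (0.01 log units; within the scatter), so at this position the straight and the branched alkyl groups cannot be told apart. Pentyl in place of nitro gives an at least 5.8-fold lower number from compound 2 to compound 3 (0.77 log units; beyond the scatter), which shows that the gap to nitro does not depend on the branched group alone, as two different alkyl groups now stand on the stronger side of it. From the compounds shown here alone, the true size of that step remains unknown, as compound 2 stands at a limit and not at a number: the limit of > 40000 nM in this assay, at which 1 of the 3 values shown sits.

Going by these compounds, two alkyl groups and one nitro group give no trend with chain length, so it remains open whether a methyl group or a longer chain such as octyl would hold this level. Also open, on these data alone, is how an amine or a carboxylic acid would read at this position.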